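Replacing a Hydroxyphenyl with a Methoxyphenyl in a Hydrazone Series

The source may report more compounds than this note shows. Statements on the series, on what has been measured and on what is new or still open speak of the compounds shown alone.

Three compounds share one core and differ only in the group on a carbon with a double bond to nitrogen. In an assay on cells for inhibition of Amine oxidase [flavin-containing] B (Homo sapiens), read by fluorescence and Amplex Red, with stated times of 30 min and 5 min (a lower number here means a stronger inhibitor, a higher number a weaker inhibitor), compound 1 `C#CCn1c(-c2ccc(C(=O)N/N=C/c3cccn3C)cc2)nc2ccccc21` gives 12200 nM, compound 2 `C#CCn1c(-c2ccc(C(=O)N/N=C/c3ccc(Cl)cc3)cc2)nc2ccccc21` gives 10200 nM, and compound 3 `C#CCn1c(-c2ccc(C(=O)N/N=C/c3ccc(O)cc3)cc2)nc2ccccc21` gives 1970 nM, the lowest of the three; the steps of a 6.2-fold lower number from compound 1 to compound 3 (0.79 log units; beyond the scatter) and a 5.2-fold lower number from compound 2 to compound 3 (0.71 log units; beyond the scatter) lie beyond the scatter, while a 1.2-fold lower number from compound 1 to compound 2 (0.08 log units; within the scatter) does not. Compound 4 `C#CCn1c(-c2ccc(C(=O)N/N=C/c3ccccc3OC)cc2)nc2ccccc21` is not yet measured; it differs from compound 3 by 2-methoxyphenyl in place of 4-hydroxyphenyl on a carbon with a double bond to nitrogen. The hydroxy group that only compound 3 carries went with its lower number, and compound 4 gives that group up, so a move back toward compound 1 and compound 2 is expected, about a 3.6-fold higher number from compound 3 to compound 4 (0.55 log units; beyond the scatter). Compound 4 is therefore estimated at 7000 nM, within 2500 nM to 20000 nM.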

Compound 4, half-maximal inhibitory concentration: >= 1000000 nM
Compound 4 gave a limit, no number; the forecaster's own chance of this, stated with the estimate: 5%; at least 140-fold (2.15 log units) between middle value and limit.
By their numbers in this assay, from the lowest: compound 3; then compounds 2 and 1 (each within the scatter of the next). At a limit, above all of these: compound 4.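

Compound 4 gave a limit in this assay, not a number: the limit of >= 1000000 nM in this assay, at which 1 of the 4 values shown sits.

Going by these compounds alone, the group on this carbon can therefore cost far more than the earlier compounds showed: an at least 500-fold higher number from compound 3 to compound 4 (2.70 log units; beyond the scatter), an at least 98-fold higher number from compound 2 to compound 4 (1.99 log units; beyond the scatter) and an at least 81-fold higher number from compound 1 to compound 4 (1.91 log units; beyond the scatter). Compound 1 and compound 2 also lack the hydroxy group yet gave numbers, so losing that group alone does not account for the result.

The compounds shown leave open whether the loss belongs to the methoxy group itself or to where it stands on the ring. Going by these compounds, how an amine or a carboxylic acid would fare at this position also stays unknown.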